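The source may report more compounds than this note shows. Statements on the series, on what has been measured and on what is new or still open speak of the compounds shown alone.

Measured in an ADME assay (liver) for metabolic stability, with Liver microsome (Homo sapiens) as the target, using microsomes and NADPH, with a stated time of 30 min, tested at 1 uM; a lower number here means slower removal, a higher number faster removal of the compound:
- Compound 1 `COCC#Cc1cc(C(O)(C(F)(F)F)C(F)(F)F)cnc1N1CCN(S(=O)(=O)c2ccc(N)nc2)CC1`: 15 mL.min-1.g-1
- Compound 2 `CC(C)(C)n1cc(-c2cc(C(O)(C(F)(F)F)C(F)(F)F)cnc2N2CCN(S(=O)(=O)c3ccc(N)nc3)CC2)cn1`: 86 mL.min-1.g-1
- Compound 3 `Nc1ccc(S(=O)(=O)N2CCN(c3ncc(C(O)(C(F)(F)F)C(F)(F)F)cc3-c3ccc4ocnc4c3)CC2)cn1`: < 14 mL.min-1.g-1 (a limit of the assay)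

Compound 3 gives < 14 mL.min-1.g-1, which is a limit and not a number. Against the other two compounds, the record shows an at least 1.0-fold lower number from compound 1 to compound 3 (0.02 log units; that floor lies within the scatter) and an at least 6.1-fold lower number from compound 2 to compound 3 (0.78 log units; beyond the scatter). Compound 4 `Cc1nc2cc(-c3cc(C(O)(C(F)(F)F)C(F)(F)F)cnc3N3CCN(S(=O)(=O)c4ccc(N)nc4)CC3)ccc2o1` has methyl in place of hydrogen on an aromatic carbon, turning 1,3-benzoxazol-5-yl into 2-methyl-1,3-benzoxazol-5-yl: methyl in place of hydrogen on an aromatic carbon.

For the measured compounds named here, no measured step tests this methyl directly. The nearest evidence comes from swaps of a whole group, which gave a 5.7-fold higher number from compound 1 to compound 2 (0.76 log units; beyond the scatter) as well as the two steps above. The larger of these swaps exchange far more than one methyl, so only a small rise, if any, is expected here. The expected change is an at least 1.1-fold higher number from compound 3 to compound 4 (0.05 log units; that floor lies within the scatter), and it may well not clear the scatter. For compound 4 the estimated value in this assay is 16 mL.min-1.g-1, with an expected range of 11 mL.min-1.g-1 to 35 mL.min-1.g-1.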

Compound 4, intrinsic clearance in microsomes: < 14 mL.min-1.g-1
Compound 4: a limit, no number (the forecaster's own chance of this, stated with the estimate: 40%); middle value at least 1.1-fold (0.05 log units) from the limit.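

In this assay compound 4, like compound 3, gives a limit and not a number, so the step for methyl in place of hydrogen, on the aromatic carbon next to the ring nitrogen and next to the ring oxygen, cannot be read: the limit of < 14 mL.min-1.g-1 in this assay, at which 2 of the 4 values shown sit.

With 2-methyl-1,3-benzoxazol-5-yl in place of 1-(tert-butyl)-1H-pyrazol-4-yl, the record shows an at least 6.1-fold lower number from compound 2 to compound 4 (0.78 log units; beyond the scatter), so the methyl-bearing group keeps the clear separation seen for the unsubstituted 1,3-benzoxazol-5-yl. With the same group in place of 3-methoxyprop-1-yn-1-yl, it shows only an at least 1.0-fold lower number from compound 1 to compound 4 (0.02 log units; that floor lies within the scatter), which sets no order.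

Going by these compounds, the actual numbers behind the limits of compound 3 and compound 4 stay open, and with them the size of any methyl effect. Also open, on these data alone, is whether an amine or a longer chain on this carbon would give a readable value.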